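Trimming an Aryl Ketone to an Alkyne on an Inactive Core

A few compounds are considered here, and "the series" means these few. Any claim that something is new, unique, unknown or untested is made for them only; others in the source may bear on it.

Of the compounds shown here, two sharing a fused two-ring core have so far been tested in a functional assay on KYSE-410 cells (Homo sapiens) for antiproliferative activity, read by MTT assay, with a stated time of 72 h; a higher number here means a weaker inhibitor, a lower number a stronger inhibitor. Compound 1, `O=C(c1cc(=O)[nH]c2cc(Br)ccc12)N1CCCCC1`, gives > 20000 nM, which is a limit of the assay rather than a number. Compound 2, `CC(=O)c1ccc(-c2ccc3c(C(=O)Nc4cccc(F)c4)cc(=O)[nH]c3c2)cc1`, likewise returns only > 20000 nM, again a limit. Compound 2 therefore stands at the limit of > 20000 nM in this assay, at which 2 of the 2 values shown sit. Compound 3, `C#Cc1ccc2c(C(=O)Nc3cccc(F)c3)cc(=O)[nH]c2c1`, has not yet been measured; it differs from compound 2 by ethynyl in place of 4-acetylphenyl on an aromatic carbon, the exchange sitting on an aromatic carbon of a six-membered aromatic ring of carbon only, part of a fused or bridged system of two rings. Among the measured compounds shown here, with no measured step between the known compounds and both known values at the limit, no step beyond the scatter is expected in this assay. Compound 3 is expected to give about 25000 nM, within 8000 nM to 80000 nM, an estimated step that the limit leaves unreadable from compound 2 to compound 3 that would most likely again be reported only as a limit.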

Compound 3, half-maximal inhibitory concentration: 9700 nM
The estimate for compound 3 lay 2.6-fold (0.41 log units) above the measured number, and the stated range covers the measured number.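

In this assay, among the compounds shown here, ethynyl in place of 4-acetylphenyl gives an at least 2.0-fold lower number from compound 2 to compound 3 (0.31 log units; beyond the scatter), and compound 3 is the first compound on this core to return a real number rather than a limit. This shows that the aromatic carbon carrying the change can affect the read-out, and that a group of 2 heavy atoms with no ring does better here than one of 9 heavy atoms with a six-membered aromatic ring. The true size of the step stays unknown, since the value for compound 2 is only a limit: the limit of > 20000 nM in this assay, at which 2 of the 3 values shown sit.

The compounds shown cannot say whether the gain comes from losing the ring, losing the carbonyl or gaining the triple bond. A plain phenyl, a nitrile or an amine on this carbon would help to tell these apart.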